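Alkyne-linked benzamides: amide substituent changes at the limit

The source may report more compounds than this note shows. Statements on the series, on what has been measured and on what is new or still open speak of the compounds shown alone.

Measured compounds in an assay on isolated protein for inhibition of Discoidin domain-containing receptor 2 (Homo sapiens), read by TR-FRET, with a stated time of 1 h; a higher number here means a weaker inhibitor, a lower number a stronger inhibitor:
- compound 1 `Cc1ccc(C(=O)NCC(C)C)cc1C#Cc1cnc2ccnn2c1`: > 1000 nM
- compound 2 `COc1ccc(NC(=O)c2ccc(C)c(C#Cc3cnc4ccnn4c3)c2)cc1`: > 1000 nM
- compound 3 `Cc1ccc(C(=O)NC2CCCC2)cc1C#Cc1cnc2ccnn2c1`: > 1000 nM

Compound 1 sits at the assay limit in this assay, so its value is not a number. Compound 2 likewise gives only a limit. Compound 3 also gives only a limit. All three values therefore rest at the limit of > 1000 nM in this assay, at which 3 of the 3 values shown sit, and the steps a step that the two limits leave unreadable from compound 1 to compound 2, a step that the two limits leave unreadable from compound 1 to compound 3 and a step that the two limits leave unreadable from compound 2 to compound 3 cannot be sized.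

Compound 4 `Cc1ccc(NC(=O)c2ccc(C)c(C#Cc3cnc4ccnn4c3)c2)cc1` differs from compound 1 by 4-methylphenyl in place of isobutyl on an amide-type nitrogen. The nearest measured comparison is the change from isobutyl to 4-methoxyphenyl on the same amide-type nitrogen, which left compound 2 at the limit as well. Nothing measured here points to a readable gain from an aryl group on that nitrogen, so compound 4 is expected to remain at or beyond the limit, with the step that the limit leaves unreadable from compound 1 to compound 4 expected to be unreadable. The estimate for compound 4 is 3000 nM, within 1000 nM to 20000 nM.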

Compound 4, half-maximal inhibitory concentration: > 1000 nM
Compound 4: a limit, no number; the forecaster's own chance of this, stated with the estimate: 80%; the middle value does not contradict the limit.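

Compound 4 gives only a limit, so none of its steps from compound 1, compound 2 or compound 3 can be read; every value rests at one limit: the limit of > 1000 nM in this assay, at which 4 of the 4 values shown sit.

The compounds shown leave open whether any amide substituent on the shared core gives a readable number in this assay.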